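This account rests on a few compounds, and the source may have more. Where it says the series, first, only, none or still open, it means among the compounds named here.

Compound 1 `COc1cccc(Oc2c(NS(=O)(=O)c3ccc(C(C)(C)C)cc3)ncnc2OCCOCc2ccccc2)c1`: 170 nM
Compound 2 `COc1cccc(Oc2c(NS(=O)(=O)c3ccc(C(C)(C)C)cc3)ncnc2OCCOc2nccs2)c1`: 12 nM

In an assay on cells (Endothelial cell) for binding affinity to Endothelin-1 receptor (Sus scrofa) (a lower number here means a stronger inhibitor, a higher number a weaker inhibitor), compound 2 gives the lowest number of the two shown; the single measured step, a 14-fold lower number from compound 1 to compound 2 (1.15 log units; beyond the scatter), is large. Compound 3 `COc1cccc(Oc2c(NCCOc3ncccn3)ncnc2NS(=O)(=O)c2ccc(C(C)(C)C)cc2)c1` differs from compound 2 by (2-((pyrimidin-2-yl)oxy)ethyl)amino in place of 2-((1,3-thiazol-2-yl)oxy)ethoxy on an aromatic carbon. Within the data shown here, no measured step changes the linking atom or swaps one heteroaryl ring for another in this way, so the earlier step gives only loose guidance. The change is therefore expected to shift this assay little, a 1.7-fold higher number from compound 2 to compound 3 (0.22 log units; within the scatter). Compound 3 is estimated at 20 nM, with a range from 5 nM to 80 nM.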

Compound 3, half-maximal inhibitory concentration: 6.2 nM
The estimate for compound 3 lay 3.2-fold (0.51 log units) above the measured number; measured number inside the range.
By their numbers in this assay, from the lowest: compounds 3 and 2 (each within the scatter of the next); then compound 1.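

In this assay the change gives a 1.9-fold lower number from compound 2 to compound 3 (0.29 log units; within the scatter), so this position accepts an amino link and a pyrimidin-2-yl ring as readily as an oxygen link and a 1,3-thiazol-2-yl ring. The step to the benzyl-bearing chain remains wide, with a 27-fold lower number from compound 1 to compound 3 (1.44 log units; beyond the scatter), and so both heteroaryl-bearing chains stand apart from 2-(benzyloxy)ethoxy. Nothing measured here accounts for this.

The link atom and the ring change together between compound 2 and compound 3, so neither change is read alone. From the compounds shown here alone, whether a longer chain or a terminal carboxylic acid would fit this position remains open.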